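Cyclopropane amide series: stereocentre inversion at the ring carbon

The source may report more compounds than this note shows. Statements on the series, on what has been measured and on what is new or still open speak of the compounds shown alone.

Measured so far:
compound 1, `CCOC(=O)[C@]1(C(=O)NCc2ccc(C)cc2)C[C@H]1c1cc(OC)c(OC)c(OC)c1` — 13300 nM
compound 2, `CCOC(=O)[C@]1(C(=O)Nc2ccccc2Cl)C[C@H]1c1cc(OC)c(OC)c(OC)c1` — 13400 nM
compound 3, `COc1cc([C@@H]2C[C@]2(CO)C(=O)NCc2ccc(C)cc2)cc(OC)c1OC` — 10500 nM

In a functional assay on A549 cells (Homo sapiens) for cytotoxicity, read by MTT assay, with a stated time of 48 h (on this read-out higher numbers stand for weaker inhibition and lower numbers for stronger inhibition), compound 1 stands second highest of the three numbers, with compound 2 nearest and compound 3 furthest, both within the scatter. Compound 4, `CCOC(=O)[C@]1(C(=O)NCc2ccc(C)cc2)C[C@@H]1c1cc(OC)c(OC)c(OC)c1`, is the unmeasured pair to compound 1: the two compounds have the same atoms and bonds and differ only in configuration as drawn: 1 of 2 stereo elements differ; a stereocentre at a saturated ring carbon is drawn S in compound 1 and R in compound 4. Neither measured step bears on this change: a 1.0-fold higher number from compound 1 to compound 2 (0.00 log units; within the scatter) alters the amide substituent, and a 1.3-fold lower number from compound 1 to compound 3 (0.10 log units; within the scatter) swaps an ester for a hydroxymethyl; nothing shown concerns configuration. With no guidance on the effect of inversion, no step beyond the scatter is expected, so compound 4 is estimated at 13300 nM, range 4500 nM to 40000 nM, a step of no change at the digits printed from compound 1 to compound 4 (within the scatter) that is expected, with wide uncertainty.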

Compound 4, half-maximal inhibitory concentration: 34900 nM
The estimate for compound 4 lay 2.6-fold (0.42 log units) below the measured number; the measured number falls inside the stated range.
By their numbers in this assay, from the lowest: compounds 3, 1 and 2 (each within the scatter of the next); then compound 4.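

Inversion at this saturated ring carbon gives, in this assay, a 2.6-fold higher number from compound 1 to compound 4 (0.42 log units; beyond the scatter), a modest step beyond the scatter, whereas the earlier changes to the amide substituent and the ester stayed within it. Of this pair, the R drawing at this carbon is the weaker, and the step rests on configuration alone: the fact that compounds 1 and 4 differ only in the configuration as drawn

As far as these compounds go, whether inversion has the same effect with the 2-chlorophenyl of compound 2 or the hydroxymethyl of compound 3 remains open. Also open, from the compounds shown here alone, is how a carboxylic acid or an amine in place of ethoxycarbonyl would stand under either configuration.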